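This account rests on a few compounds, and the source may have more. Where it says the series, first, only, none or still open, it means among the compounds named here.

In an ADME assay on the whole organism (Rattus norvegicus) for pharmacokinetics, read by HPLC, at a dose of 3 mg/kg by the oral route (on this read-out lower numbers stand for lower exposure and higher numbers for higher exposure at the dose given), compound 1 `N#Cc1cc(C(=O)N2CCc3ccccc32)ccc1O` gives 3370 nM and compound 2 `N#Cc1cc(C(=O)N2CCc3ccccc32)cc(I)c1O` gives 15200 nM. Compound 3 `N#Cc1cc(C(=O)N2CS(=O)(=O)c3ccccc32)cc(C2CC2)c1O` gives 10800 nM, which lies within the scatter of compound 2 and beyond the scatter above compound 1.

Compound 4 `CC(C)c1cc(C(=O)N2CS(=O)(=O)c3ccccc32)cc(C#N)c1O` has isopropyl in place of cyclopropyl on an aromatic carbon, ortho to a hydroxy group: isopropyl in place of cyclopropyl on an aromatic carbon. For the measured compounds named here, compound 4 has not yet been measured, and no measured pair shows this exact exchange. Going by the values given here, the only measured step that bears on it is a 4.5-fold higher number from compound 1 to compound 2 (0.65 log units; beyond the scatter). That step put iodo in place of hydrogen on an aromatic carbon, so it offers only a loose guide. The new change is different in kind, since one three-carbon group replaces another and only the ring is lost. No step beyond the scatter is therefore expected in this assay, and no direction can be favoured with confidence. The expected step is a 1.1-fold lower number from compound 3 to compound 4 (0.06 log units; within the scatter). The estimate for compound 4 is 9500 nM, with an expected range from 4500 nM to 20000 nM.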

Compound 4, maximal plasma concentration: 12500 nM
Estimate against measurement, compound 4: 1.3-fold (0.12 log units) below, within the range that was stated.
By their numbers in this assay, from the lowest: compound 1; then compounds 3, 4 and 2 (each within the scatter of the next).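

In this assay the exchange of cyclopropyl for isopropyl, on an aromatic carbon ortho to a hydroxy group, gives a 1.2-fold higher number from compound 3 to compound 4 (0.06 log units; within the scatter) and so cannot be told apart from no change at all. Both groups hold 3 carbon heavy atoms, and this pair shows that losing the three-membered ring at this place brings no step beyond the scatter, whereas the earlier step, a 4.5-fold higher number from compound 1 to compound 2 (0.65 log units; beyond the scatter), showed only that iodo in place of hydrogen can move this number. Nothing measured here speaks to why the two groups behave alike.

As far as these compounds go, what an amine, a carboxylic acid or a longer chain would do at this carbon remains open. From the compounds shown here alone, whether the step from hydrogen to iodo carries over to the core of compound 3 also stays unknown.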